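Working notes: from butyl to tert-butyl on the aromatic ring

The compounds below may be only part of what the source reports. "The series", "measured", "known", "first", "only" and "open" are said of these compounds alone.

Three compounds share one core and differ only in the group on one aromatic carbon. Compound 1 `O=[N+]([O-])c1ccc(S(=O)(=O)NCCCCCCNCc2ccc(Br)cc2)cc1` carries a nitro group; in a functional assay on MIA PaCa-2 cells (Homo sapiens) for inhibition, read by MTT assay, with a stated time of 72 h (on this read-out lower numbers stand for stronger inhibition of growth and higher numbers for weaker inhibition of growth), compound 1 gives 9800 nM. Compound 2 `COc1ccc(S(=O)(=O)NCCCCCCNCc2ccc(Br)cc2)cc1` carries a methoxy group, and in this assay compound 2 gives 13000 nM. Compound 3 `CCCCc1ccc(S(=O)(=O)NCCCCCCNCc2ccc(Br)cc2)cc1` carries a butyl group, and in this assay compound 3 gives 5700 nM, the lowest of the three numbers, though the step is only a 1.7-fold lower number from compound 1 to compound 3 (0.24 log units; within the scatter), while a 2.3-fold lower number from compound 2 to compound 3 (0.36 log units; beyond the scatter). Between the other two, a 1.3-fold higher number from compound 1 to compound 2 (0.12 log units; within the scatter).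

Compound 4 `CC(C)(C)c1ccc(S(=O)(=O)NCCCCCCNCc2ccc(Br)cc2)cc1` differs from compound 3 by tert-butyl in place of butyl on an aromatic carbon. Going by the values given here, none of the measured steps exchanges one saturated four-carbon group for another; each swaps unlike groups, and even those spans stay small, the largest being the modest one from compound 2 to compound 3. The step expected in this assay is therefore a 1.0-fold lower number from compound 3 to compound 4 (0.02 log units; within the scatter), with no direction expected beyond the scatter. Compound 4 is estimated in this assay at 5500 nM, within a range from 2800 nM to 11000 nM.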

Compound 4, concentration for 50% growth inhibition: 2970 nM
Beside the measured number, compound 4's estimate is 1.9-fold (0.27 log units) above it; measured number inside the range.
By their numbers in this assay, from the lowest: compounds 4, 3, 1 and 2 (each within the scatter of the next, the first and the last beyond it).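

In this assay the two arrangements of the same four carbons are not separated, with a 1.9-fold lower number from compound 3 to compound 4 (0.28 log units; within the scatter) leaving tert-butyl and butyl indistinguishable on this aromatic carbon. The new compound does widen the spread against the unlike groups: a 3.3-fold lower number from compound 1 to compound 4 (0.52 log units; beyond the scatter) is a gap that the step from nitro to butyl did not show, since that step stayed within the scatter. The step from methoxy, a 4.4-fold lower number from compound 2 to compound 4 (0.64 log units; beyond the scatter) and so the largest span at this carbon so far, remains modest, so the change of group moves the number only a little across all four compounds.

Still open, as far as these compounds go, is how an isopropyl group, a longer chain such as octyl, or an amine on the same aromatic carbon would read in this assay. Nothing available here speaks to why the numbers differ.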